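The source may hold more compounds than are shown below. What is called first, only, known or untested is meant among the compounds shown, and "the series" means these compounds.

Measured in an ADME assay on THP-1 cells (Homo sapiens) for cytotoxicity, read by MTT assay, with a stated time of 72 h; on this read-out higher numbers stand for weaker inhibition and lower numbers for stronger inhibition:
- Compound 1 `O=C(/C=C/c1ccc([N+](=O)[O-])cc1)c1c(O)c2ccccc2[nH]c1=O`: > 50000 nM, a limit
- Compound 2 `COc1cccc(/C=C/C(=O)c2c(O)c3ccccc3[nH]c2=O)c1`: 38500 nM
- Compound 3 `O=C(/C=C/c1ccc(C(F)(F)F)cc1)c1c(O)c2ccccc2[nH]c1=O`: > 50000 nM, a limit

The entry for compound 3, > 50000 nM, is a limit and not a number. Compound 4 `COc1ccc(/C=C/C(=O)c2c(O)c3ccccc3[nH]c2=O)cc1` has methoxy in place of trifluoromethyl on an aromatic carbon, para to a large group (methoxy in place of trifluoromethyl on an aromatic carbon). For the measured compounds named here, the one measured step, a step that the two limits leave unreadable from compound 1 to compound 3, offers no size to carry over. Also relevant is the limit of > 50000 nM in this assay, at which 2 of the 3 values shown sit. The nearest guide is compound 2, which also carries methoxy and gives 38500 nM. In this assay, the expected change is therefore small, toward stronger inhibition: an at least 1.2-fold lower number from compound 3 to compound 4 (0.09 log units; that floor lies within the scatter). For compound 4 the estimate is 40000 nM, with an expected range of 15000 nM to 50000 nM.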

Compound 4, half-maximal inhibitory concentration: > 50000 nM
Compound 4 ended at the assay's limit; the forecaster's own chance of this, stated with the estimate: 40%; middle value at least 1.2-fold (0.09 log units) away from the limit.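

In this assay, 4-methoxyphenyl in place of 3-methoxyphenyl gives an at least 1.2-fold higher number from compound 2 to compound 4 (0.11 log units; that floor lies within the scatter), so only a floor inside the scatter is available for this change of methoxy position. The steps to compound 4 from compound 1 and compound 3 cannot be read, so methoxy at this place, para to a large group, cannot be ranked against nitro or trifluoromethyl. Only a limit is available for most of the series: the limit of > 50000 nM in this assay, at which 3 of the 4 values shown sit.

From the compounds shown here alone, how far compound 1, compound 3 and compound 4 lie beyond that limit remains open. Going by these compounds, the effect of an amine or a carboxylic acid at this place on the shared core also remains open.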